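This account rests on a few compounds, and the source may have more. Where it says the series, first, only, none or still open, it means among the compounds named here.

Among the compounds with values here, compound 3 `Oc1ccccc1CNc1ccc(-c2ccc(F)cc2)cc1` is the only member of this small set to give a number in a functional assay on Jurkat cells (Homo sapiens) for activation, with a stated time of 24 h (on this read-out lower numbers stand for an effect already at smaller amounts and higher numbers for an effect only at larger amounts of compound), where compound 3 reaches 3860 nM. Compound 1 `Oc1ccccc1CNc1ccccc1` gives "not active" (no number reported) in this assay. Compound 2 `Oc1ccccc1CNc1ccc(N2CCCCC2)cc1` likewise gives "not active" (no number reported) in this assay. Against this background, compound 3 stands alone with a measurable but weak effect, and nothing in the set allows a comparison of one numbered result with another.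

Compound 4 `Oc1ccccc1CNc1ccc(-c2ccc(-c3ccccc3)cc2)cc1` differs from compound 3 in one place: phenyl in place of fluoro on an aromatic carbon. Within the data shown here, no pair of measured compounds shows a step of this kind, so the size of the effect has to be guessed rather than read off. Among the measured compounds shown here, the set shows only that the compound carrying a biaryl arm, compound 3, gives a number where the others do not, which argues that the arm is tolerated and perhaps that a longer arm remains so. Compound 4 is therefore expected to stay close to compound 3, with a step from a 1.3-fold lower number from compound 3 to compound 4 (0.11 log units; within the scatter) that lies within or barely beyond the usual scatter in either direction. The estimate for compound 4 in this assay is 3000 nM, with a range from 800 nM to 12000 nM.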

Compound 4, half-maximal effective concentration: "not active" (no number reported)
The entry for compound 4 holds no number; the estimate stays without a comparison.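

In this assay, within the data shown here, compound 4 gives "not active" (no number reported) and so, with no number to set against that of compound 3, no step between the two can be read. No measured evidence bears on this result. The compounds shown leave open which changes to the arm of compound 3 would keep a measurable effect.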